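Methoxy in place of tert-butyl at the aryl ether

The source may report more compounds than this note shows. Statements on the series, on what has been measured and on what is new or still open speak of the compounds shown alone.

Compound 1 `NC1=NC2(CCSCC2)N(OCCCOc2cccc(Cl)c2)C(N)=N1` gives 60 nM in a functional assay on A549 cells (Homo sapiens) for antiproliferative activity, read by MTT assay, with a stated time of 72 h; a higher number here means a weaker inhibitor, a lower number a stronger inhibitor.
Compound 2 `NC1=NC2(CCSCC2)N(OCCCOc2cccc(Cl)c2Cl)C(N)=N1` gives 1 nM.
Compound 3 `CC(C)(C)c1ccc(OCCCON2C(N)=NC(N)=NC23CCSCC3)cc1` gives 1 nM.

Compound 3 stands level with compound 2 at the digits shown, and the two together give the lowest numbers of the three, while compound 1 sits far above them. Among the measured compounds shown here, the only measured step, a 60-fold lower number from compound 1 to compound 2 (1.78 log units; beyond the scatter), concerns a chloro entering on the aromatic ring and does not touch the change at hand. Compound 4 `COc1ccc(OCCCON2C(N)=NC(N)=NC23CCSCC3)cc1` differs from compound 3 by methoxy in place of tert-butyl on an aromatic carbon. For the measured compounds named here, no measured step bears on this exchange, so the expectation rests on compound 3 alone, with wide uncertainty. Compound 4 is expected to give up some potency, a 5.0-fold higher number from compound 3 to compound 4 (0.70 log units; beyond the scatter). The estimate for compound 4 in this assay is 5 nM, between 1 nM and 30 nM.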

Compound 4, half-maximal inhibitory concentration: 240 nM
Compound 4: the middle estimate sits 48-fold (1.68 log units) below what was measured; measured number above the stated range.
By their numbers in this assay, from the lowest: compounds 2 and 3 (each within the scatter of the next); then compound 1; then compound 4.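

In this assay, the substituent on this aromatic carbon proves far from interchangeable: methoxy in place of tert-butyl gives a 240-fold higher number from compound 3 to compound 4 (2.38 log units; beyond the scatter). The 4-methoxyphenyl group also falls behind both chlorinated aryl groups, with a 240-fold higher number from compound 2 to compound 4 (2.38 log units; beyond the scatter) and a 4.0-fold higher number from compound 1 to compound 4 (0.60 log units; beyond the scatter), which leaves compound 4 the weakest of the four. Nothing available here accounts for this loss.

Going by these compounds, it remains open whether isopropyl or cyclohexyl at this carbon would keep the low number of compound 3. On these data alone, it is equally open how a hydroxyl or an amine there would fare.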